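Vero cell cytotoxicity notes on compounds 1 to 3

This account rests on a few compounds, and the source may have more. Where it says the series, first, only, none or still open, it means among the compounds named here.

Measured so far in an ADME assay on Vero cells (Chlorocebus sabaeus) for cytotoxicity; on this read-out lower numbers stand for higher toxicity in this test and higher numbers for lower toxicity in this test:
compound 1 `O=C(c1ccc([N+](=O)[O-])cc1)n1ccnc1-c1cccc([N+](=O)[O-])c1` gives > 100 ug/mL
compound 2 `O=C(c1ccc([N+](=O)[O-])cc1)n1ccnc1-c1ccccc1[N+](=O)[O-]` gives > 100 ug/mL

Both of these values are limits of the assay and not numbers. For compound 2 only a limit is known, and it stands at the limit of > 100 ug/mL in this assay, at which 2 of the 2 values shown sit. The value shown for compound 1 is a limit of the same kind. Within the data shown here, no step between measured compounds can be resolved, since neither value is a number.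

Compound 3 `O=C(c1ccc([N+](=O)[O-])cc1)n1ccnc1-c1ccccc1Cl` is not yet measured in this assay. Its change from compound 2: chloro in place of nitro on an aromatic carbon. Nothing measured in the series shows how chloro in place of nitro moves the minimum cytotoxic concentration, so a step no larger than the usual scatter is expected, a number no higher from compound 2 to compound 3 (the limit leaves the size open), with no direction claimed. For compound 3 the expected value in this assay is 100 ug/mL, within 30 ug/mL to 200 ug/mL, and the assay may well again report only a limit.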

Compound 3, minimum cytotoxic concentration: > 100 ug/mL
Compound 3 ended at the assay's limit (the forecaster's own chance of this, stated with the estimate: 60%); the middle value sits exactly at the limit.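

No step from compound 2 to compound 3 can be read in this assay, since both values are limits of the assay and not numbers: the limit of > 100 ug/mL in this assay, at which 3 of the 3 values shown sit.

The compounds shown leave open where each true minimum cytotoxic concentration lies, and whether chloro in place of nitro moves it at all.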